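A few compounds are considered here, and "the series" means these few. Any claim that something is new, unique, unknown or untested is made for them only; others in the source may bear on it.

Compound 1 `N#CC1=C(N)Oc2cc3oc(-c4ccccc4)cc(=O)c3c(O)c2C12C(=O)N(Cc1ccccc1)c1ccc(Cl)cc12` and compound 2 `N#CC1=C(N)Oc2cc3oc(-c4ccccc4)cc(=O)c3c(O)c2C12C(=O)N(Cc1ccccc1)c1ccc(Br)cc12` share one core; compound 3 `N#CC1=C(N)Oc2cc3oc(-c4ccccc4)cc(=O)c3c(O)c2C12C(=O)Nc1cc(Cl)ccc12` and the not yet measured compound 4 `N#CC1=C(N)Oc2cc3oc(-c4ccccc4)cc(=O)c3c(O)c2C12C(=O)Nc1cc(Br)ccc12` share another, and the difference between the two cores is not broken down here. In a functional assay on A549 cells (Homo sapiens) for antiproliferative activity, read by MTT assay, with a stated time of 48 h (on this read-out higher numbers stand for weaker inhibition and lower numbers for stronger inhibition), compound 1 gives > 50000 nM, which is a limit of the assay and not a number. In this assay compound 2 gives > 50000 nM, again a limit. The change between them, (bromo in place of chloro on an aromatic carbon), gives a step that the two limits leave unreadable from compound 1 to compound 2. In this assay compound 3 gives 8470 nM. The same change, (bromo in place of chloro on an aromatic carbon), leads to compound 4. Since both measured values of that change sit at the limit of > 50000 nM in this assay, at which 2 of the 3 values shown sit, it offers no reading of size, so the expected step is a 1.1-fold lower number from compound 3 to compound 4 (0.05 log units; within the scatter), resting only on compound 3 at 8470 nM. Compound 4 is therefore estimated to give about 7500 nM, expected between 2500 nM and 25000 nM.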

Compound 4, half-maximal inhibitory concentration: 9340 nM
For compound 4 the middle estimate is 1.2-fold (0.10 log units) below the measured one; the measured number falls inside the stated range.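

In this assay, bromo in place of chloro gives a 1.1-fold higher number from compound 3 to compound 4 (0.04 log units; within the scatter), so on this core the two halogens cannot be told apart. On the core of compound 1 the same change cannot be read, since compound 1 and compound 2 each give a limit of the assay and not a number: the limit of > 50000 nM in this assay, at which 2 of the 4 values shown sit. The change is therefore read on one core only, and nothing shows whether its small size would carry over to the other core.

The compounds shown leave open whether an amine or a methoxy group on that aromatic carbon would give a number beyond the scatter from compound 3. They also leave open whether either group would bring the core of compound 1 off its limit.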